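The source may hold more compounds than are shown below. What is called first, only, known or untested is meant among the compounds shown, and "the series" means these compounds.

Compound 1 `CC#CC(CC(=O)O)c1ccc(OCc2ccc(C(=O)N3CCN(C)CC3)s2)cc1` in a functional assay on HEK293 cells for agonist activity at Free fatty acid receptor 1 (Homo sapiens), read by fluorescence and calcium flux (on this read-out higher numbers stand for an effect only at larger amounts of compound and lower numbers for an effect already at smaller amounts), returns only a limit of the assay, > 5000 nM. For the measured compounds named here, compound 2 `CC#CC(CC(=O)O)c1ccc(OCc2ccc(C(=O)N3CCc4ccccc4C3)o2)cc1` gives 50 nM in this assay, the only number among the values shown. Compound 3 `CC#CC(CC(=O)O)c1ccc(OCc2ccc(C(=O)NC3CCCc4ccccc43)o2)cc1` differs from compound 2 by (1,2,3,4-tetrahydronaphthalen-1-yl)amino in place of 1,2,3,4-tetrahydroisoquinolin-2-yl on a carbonyl carbon. No step between measured compounds is shown, so the size of this change is open. A modest loss, somewhat beyond the scatter, is expected, a 3.0-fold higher number from compound 2 to compound 3 (0.48 log units; beyond the scatter). Compound 3 is therefore estimated at 150 nM in this assay, within 40 nM to 600 nM.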

Compound 3, half-maximal effective concentration: 133 nM
Compound 3: the middle estimate sits 1.1-fold (0.05 log units) above what was measured, and the stated range covers the measured number.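

Putting (1,2,3,4-tetrahydronaphthalen-1-yl)amino on the carbonyl carbon in place of 1,2,3,4-tetrahydroisoquinolin-2-yl gives a 2.7-fold higher number from compound 2 to compound 3 (0.42 log units; beyond the scatter) in this assay. The change brings in a hydrogen-bond donor, and compound 3 still returns a measured number rather than a limit, so this position accepts that swap at a modest cost. Nothing shown accounts for the size of this step.

From the compounds shown here alone, the amide hydrogen and the altered ring change together, and their separate shares remain open. Going by these compounds, how piperidin-1-yl or benzylamino would read on that carbonyl carbon is also open.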